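The compounds below may be only part of what the source reports. "The series", "measured", "known", "first", "only" and "open" are said of these compounds alone.

Working notes on the series. Compound 3 `CCCCCCCCS(=O)(=O)Nc1ccc(-c2ccc(-c3ccccc3)cc2)cc1C(=O)O` stands highest of the three numbers measured in an assay on mitochondria (strain BALB/c) for inhibition of glycerol-3-phosphate acyltransferase 1, mitochondrial (Mus musculus), read by scintillation counting, with a stated time of 10 min; a lower number here means a stronger inhibitor, a higher number a weaker inhibitor; compound 3 gives 29100 nM. Compound 2 `CCCCCCCCS(=O)(=O)Nc1ccc(-c2ccc(CCCC)cc2)cc1C(=O)O` gives 9000 nM and compound 1 `CCCCCCCCS(=O)(=O)Nc1ccc(-c2cccc(Cl)c2)cc1C(=O)O` gives 8900 nM. Going by the values given here, the step of a 3.2-fold higher number from compound 2 to compound 3 (0.51 log units; beyond the scatter) is the only measured step at the position in question and is beyond the scatter, whereas a 1.0-fold higher number from compound 1 to compound 2 (0.00 log units; within the scatter) is within it. Compound 4 `CCCCCCCCS(=O)(=O)Nc1ccc(-c2ccc(OC)cc2)cc1C(=O)O` differs from compound 3 by methoxy in place of phenyl on an aromatic carbon, a smaller group taking the place of the phenyl, so the step is expected to run back toward the numbers of compounds 1 and 2, as a 2.9-fold lower number from compound 3 to compound 4 (0.46 log units; beyond the scatter) in this assay. Compound 4 is therefore expected at about 10000 nM, with a range from 4000 nM to 25000 nM.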

Compound 4, half-maximal inhibitory concentration: 19500 nM
The estimate for compound 4 lay 2.0-fold (0.29 log units) below the measured number; measured number inside the range.
By their numbers in this assay, from the lowest: compounds 1 and 2 (each within the scatter of the next); then compounds 4 and 3 (each within the scatter of the next).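

In this assay, methoxy in place of phenyl at this place on the aromatic ring stays within the scatter (a 1.5-fold lower number from compound 3 to compound 4 (0.17 log units; within the scatter)), so losing the outer ring does not return the number to that of compound 2. Methoxy in place of butyl (a 2.2-fold higher number from compound 2 to compound 4 (0.34 log units; beyond the scatter)) and 4-methoxyphenyl in place of 3-chlorophenyl (a 2.2-fold higher number from compound 1 to compound 4 (0.34 log units; beyond the scatter)) are both modest steps beyond the scatter. No measurement at hand bears on the reason for these steps. From the compounds shown here alone, whether an amine or a longer alkoxy chain at this place would bring a lower number than butyl remains open.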